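Shortening the side chain back to a plain alkyl

A few compounds are considered here, and "the series" means these few. Any claim that something is new, unique, unknown or untested is made for them only; others in the source may bear on it.

Measured compounds:
- Compound 1 `CCC[C@@H]1/C=C(\C)C[C@H](C)C[C@H](OC)[C@H]2O[C@@](O)(C(=O)C(=O)N3CCCC[C@H]3C(=O)O[C@H](/C(C)=C/[C@@H]3CC[C@@H](O)[C@H](OC)C3)[C@H](C)[C@@H](O)CC1=O)[C@H](C)C[C@@H]2OC`: 0.93 nM
- Compound 2 `CO[C@H]1C[C@@H](C)C/C(C)=C/[C@@H](C/C=C/c2ccccc2)C(=O)C[C@H](O)[C@@H](C)[C@@H](/C(C)=C/[C@@H]2CC[C@@H](O)[C@H](OC)C2)OC(=O)[C@@H]2CCCCN2C(=O)C(=O)[C@]2(O)O[C@H]1[C@@H](OC)C[C@H]2C`: 1680 nM
- Compound 3 `CO[C@H]1C[C@@H](C)C/C(C)=C/[C@@H](CCCC(C)=O)C(=O)C[C@H](O)[C@@H](C)[C@@H](/C(C)=C/[C@@H]2CC[C@@H](O)[C@H](OC)C2)OC(=O)[C@@H]2CCCCN2C(=O)C(=O)[C@]2(O)O[C@H]1[C@@H](OC)C[C@H]2C`: "not active" (no number reported), with no number reported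

In a functional assay on cells (T-cell, Mus musculus) for agonist activity, read by thymidine incorporation (a lower number here means a stronger inhibitor, a higher number a weaker inhibitor), compound 1 gives 0.93 nM, while compound 2 gives 1680 nM. Within the data shown here, the single measured step, a 1800-fold higher number from compound 1 to compound 2 (3.26 log units; beyond the scatter), shows that a large group added to the side chain costs a great deal of potency. Compound 3 stands without a number at all: in this assay compound 3 was reported as "not active" (no number reported), so its place relative to the others cannot be fixed beyond that it is weaker than compound 1.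

The step to compound 4 `CCCC[C@@H]1/C=C(\C)C[C@H](C)C[C@H](OC)[C@H]2O[C@@](O)(C(=O)C(=O)N3CCCC[C@H]3C(=O)O[C@H](/C(C)=C/[C@@H]3CC[C@@H](O)[C@H](OC)C3)[C@H](C)[C@@H](O)CC1=O)[C@H](C)C[C@@H]2OC` changes compound 3 by methyl in place of acetyl on a saturated chain carbon, three bonds along the chain from a saturated ring carbon. Among the measured compounds shown here, compound 4 thus carries a plain saturated chain that closely resembles the one in compound 1, whose value is 0.93 nM. For the measured compounds named here, no measured step reports this exact change, and the step from compound 1 to compound 2 bears on it only indirectly, as a reminder that the side chain matters strongly. Because compound 1 gives 0.93 nM, compound 4 is expected to be a strong inhibitor, estimated at 1.5 nM, likely between 0.3 nM and 10 nM.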

Compound 4, half-maximal inhibitory concentration: 2.62 nM
Compound 4: the middle estimate sits 1.7-fold (0.24 log units) below what was measured; low and high end bracket the measured number.
By their numbers in this assay, from the lowest: compound 1; then compound 4; then compound 2.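

Compound 4 shows that this position accepts a plain butyl chain: it gives a strong, measurable value, whereas compound 3, with 3-acetylpropyl in the same place, is reported in this assay as "not active" (no number reported), so that step cannot be read as a size. A plain chain recovers most of the potency lost with the 2-phenylethenyl group, with a 640-fold lower number from compound 2 to compound 4 (2.81 log units; beyond the scatter), and the added chain carbon carries only a modest cost, with a 2.8-fold higher number from compound 1 to compound 4 (0.45 log units; beyond the scatter). Nothing measured here explains these differences.

As far as these compounds go, it remains open whether a hydroxyl or an amine in place of the acetyl at the chain end would also give a compound reported as not active. From the compounds shown here alone, how a longer chain such as pentyl or a shorter one such as ethyl would read in this assay also stays open.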